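Extending the Ureido Side Chain of Compound 2

A few compounds are considered here, and "the series" means these few. Any claim that something is new, unique, unknown or untested is made for them only; others in the source may bear on it.

Compound 1 `Cc1cn([C@@H]2O[C@H](CO[Si](C)(C)C(C)(C)C)[C@@]3(OS(=O)(=O)C=C3NC(=O)c3ccccc3)[C@H]2O[Si](C)(C)C(C)(C)C)c(=O)n(C)c1=O` gives 9700 nM in a functional assay on HEL cells (Homo sapiens); a higher number here means that more compound is tolerated, a lower number that less compound is tolerated. Compound 2 `Cc1cn([C@@H]2O[C@H](CO[Si](C)(C)C(C)(C)C)[C@@]3(OS(=O)(=O)C=C3NC(N)=O)[C@H]2O[Si](C)(C)C(C)(C)C)c(=O)n(C)c1=O` gives 11000 nM. Among the measured compounds shown here, compound 3 `Cc1cn([C@@H]2O[C@@H]3COC(=O)[C@]3(OS(C)(=O)=O)[C@H]2O)c(=O)[nH]c1=O`, built on a different core, reaches only the limit of >= 36000 nM in this assay, and that value is a limit rather than a number. the limit of >= 36000 nM in this assay, at which 1 of the 3 values shown sits, is therefore the only guidance on the upper edge of the measurable range. Between the two numbers shown, compound 2 stands alongside compound 1, with a 1.1-fold higher number from compound 1 to compound 2 (0.05 log units; within the scatter). That step exchanged the group on the carbonyl attached to the amine nitrogen and left this assay essentially unmoved.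

Compound 4 `Cc1cn([C@@H]2O[C@H](CO[Si](C)(C)C(C)(C)C)[C@@]3(OS(=O)(=O)C=C3NCC(=O)C(N)=O)[C@H]2O[Si](C)(C)C(C)(C)C)c(=O)n(C)c1=O` is the unmeasured analogue: (carbamoylcarbonyl)methyl in place of carbamoyl on an amine nitrogen. For the measured compounds named here, the only measured step that bears on it is the one from compound 1 to compound 2, which reworked the substituent on the same amine nitrogen and stayed within the scatter. On that basis no step beyond the scatter is expected, and the estimate for the move is no change at the digits printed from compound 2 to compound 4 (within the scatter). Compound 4 is therefore expected to give about 11000 nM, in a range from 5000 nM to 25000 nM.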

Compound 4, half-maximal cytotoxic concentration: 14500 nM
Compound 4: middle estimate off by 1.3-fold (0.12 log units), on the low side; measured number inside the range.
By their numbers in this assay, from the lowest: compounds 1, 2 and 4 (each within the scatter of the next). At a limit, above all of these: compound 3.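

On the amine nitrogen of the shared core, (carbamoylcarbonyl)methyl in place of carbamoyl stays within the scatter in this assay (a 1.3-fold higher number from compound 2 to compound 4 (0.12 log units; within the scatter)). The same group in place of benzoyl also stays within the scatter (a 1.5-fold higher number from compound 1 to compound 4 (0.17 log units; within the scatter)). The earlier step only exchanged the group on a carbonyl carbon, whereas these steps show that the number holds when that nitrogen carries a larger substituent joined through a methylene carbon rather than through a carbonyl.

The compounds shown leave open whether an aminoalkyl chain, a carboxylic acid or a longer chain on this nitrogen would move the number beyond the scatter. Nothing shown here gives a reason why these three substituents on the nitrogen leave the number within the scatter.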